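Acetylating the aniline of a weak chalcone inhibitor

This account rests on a few compounds, and the source may have more. Where it says the series, first, only, none or still open, it means among the compounds named here.

This account follows compound 1 `COc1ccc(/C=C/C(=O)c2ccc(N)c(-c3ccc(F)cc3)c2)cc1OC` and its acetylated analogue. In an assay on A549 cells for inhibition of transcription factor p65 (Homo sapiens), read by fluorescence, with a stated time of 2 h (on this read-out higher numbers stand for weaker inhibition and lower numbers for stronger inhibition), compound 1 gives only a limit, > 50000 nM, and so its standing is known only as the limit of > 50000 nM in this assay, at which 1 of the 3 values shown sits. Two companions were measured with numbers: compound 2 `COc1ccc(-c2cc(C(=O)/C=C/c3cccc(OC)c3OC)ccc2N)cc1OC` gives 11900 nM, and compound 3 `O=C(/C=C/c1cccc(Br)c1)c1cccc(-c2cccc(F)c2)c1` gives 11200 nM. The step to compound 4 `COc1ccc(/C=C/C(=O)c2ccc(NC(C)=O)c(-c3ccc(F)cc3)c2)cc1OC` is acetyl in place of hydrogen on a nitrogen on an aromatic ring. Among the measured compounds shown here, no measured pair shows what this change does here, so the size of the step is not known from the data. Compound 4 is expected to stay weak in this assay, with an estimated 35000 nM and a range from 8000 nM to 100000 nM, an expected step of an at least 1.4-fold lower number from compound 1 to compound 4 (0.15 log units; that floor lies within the scatter) that may well again end as a limit.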

Compound 4, half-maximal inhibitory concentration: 2650 nM
For compound 4 the middle estimate is 13-fold (1.12 log units) above the measured one; measured number below the stated range.
By their numbers in this assay, from the lowest: compound 4; then compounds 3 and 2 (each within the scatter of the next). At a limit, above all of these: compound 1.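

Acetyl in place of hydrogen on the nitrogen on an aromatic ring gives an at least 18-fold lower number from compound 1 to compound 4 (1.27 log units; beyond the scatter), so in this assay this position responds to this change, which the earlier compounds, with no measured pair among them, could not show. The value of compound 1 is a limit, so the step is a floor and not a full size: the limit of > 50000 nM in this assay, at which 1 of the 4 values shown sits.

As far as these compounds go, whether the same change would act on the amino group of compound 2 stays open. So does how a formyl group, a longer acyl chain or a methanesulfonyl group on this nitrogen would read.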